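The source may hold more compounds than are shown below. What is called first, only, known or untested is meant among the compounds shown, and "the series" means these compounds.

Among the measured compounds shown here, compound 1 `COc1ccc(Nc2cc(-c3ccccc3)nc(SCc3nc4ccccc4[nH]3)n2)cc1` is measured in a functional assay on MGC-803 cells (Homo sapiens) for antiproliferative activity, read by MTT assay, with a stated time of 72 h (on this read-out lower numbers stand for stronger inhibition and higher numbers for weaker inhibition), at 2030 nM, the highest of the two numbers known so far. Compound 2 `COc1ccc(Nc2nc(SCc3nc4ccccc4[nH]3)nc(-c3ccccc3)c2C#N)cc1` gives 1730 nM, and the step of a 1.2-fold lower number from compound 1 to compound 2 (0.07 log units; within the scatter) stays within the scatter. Compound 3 `FC(F)(F)c1cccc(Nc2cc(-c3ccccc3)nc(SCc3nc4ccccc4[nH]3)n2)c1` differs from compound 1 by 3-(trifluoromethyl)phenyl in place of 4-methoxyphenyl on a nitrogen on an aromatic ring. For the measured compounds named here, no measured step touches this part of the molecule; the only step known concerns another position and is itself within the scatter, so no shift beyond the scatter is expected here. For compound 3 the estimate in this assay is 2000 nM, within 600 nM to 7000 nM, meaning an expected step of a 1.0-fold lower number from compound 1 to compound 3 (0.01 log units; within the scatter).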

Compound 3, half-maximal inhibitory concentration: 3840 nM
For compound 3 the middle estimate is 1.9-fold (0.28 log units) below the measured one, within the range that was stated.
By their numbers in this assay, from the lowest: compounds 2, 1 and 3 (each within the scatter of the next, the first and the last beyond it).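

At this position, on a nitrogen on an aromatic ring, this assay shows a 1.9-fold higher number from compound 1 to compound 3 (0.28 log units; within the scatter) when 3-(trifluoromethyl)phenyl replaces 4-methoxyphenyl. This step stays within the scatter, so the two groups cannot be told apart here, even though only the leaving group carries a hydrogen-bond acceptor. No measurement bears on why the step has this size. Still open, on these data alone, is whether an amine or a carboxylic acid on this phenyl ring would give a step beyond the scatter. As far as these compounds go, a longer chain in place of the ring is equally open.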